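A Sulfanyl Group Added to Two Inactive Cores

A few compounds are considered here, and "the series" means these few. Any claim that something is new, unique, unknown or untested is made for them only; others in the source may bear on it.

Compound 1 `OCCOCn1cnc2cc(Cl)c(Cl)cc21` was tested in a functional assay on KB cells (Homo sapiens) for inhibition; a higher number here means a weaker inhibitor, a lower number a stronger inhibitor. In this assay compound 1 gives > 100000 nM, which is a limit of the assay rather than a number. Compound 2 `OCCOCn1cnc2c(Cl)cc(Cl)cc21` is made of the same atoms joined differently; the difference between the two cores is not broken down here. In this assay compound 2 gives > 100000 nM, again only a limit. Compound 3 `OCCOCn1c(S)nc2cc(Cl)c(Cl)cc21` arises from compound 1 by sulfanyl in place of hydrogen on an aromatic carbon. In this assay compound 3 gives > 100000 nM, also a limit. The step that the two limits leave unreadable from compound 1 to compound 3 therefore cannot be read, because all three measured values sit at the limit of > 100000 nM in this assay, at which 3 of the 3 values shown sit.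

Compound 4 `OCCOCn1c(S)nc2c(Cl)cc(Cl)cc21` has not yet been measured; it arises from compound 2 by the same change, (sulfanyl in place of hydrogen on an aromatic carbon), at a place described in the same words as before. The expected step is a number no higher from compound 2 to compound 4 (the limit leaves the size open), which rests on the limit of > 100000 nM in this assay, at which 3 of the 3 values shown sit, where compound 1, compound 2 and compound 3 all sit. Compound 4 is accordingly expected to give 100000 nM, most likely reported once more as a limit rather than as a number.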

Compound 4, half-maximal inhibitory concentration: > 100000 nM
Compound 4: a limit, no number (the forecaster's own chance of this, stated with the estimate: 85%); the middle value lies on the limit itself.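

The step from compound 2 to compound 4 cannot be read, because both compounds give a limit of the assay rather than a number: (the limit of > 100000 nM in this assay, at which 4 of the 4 values shown sit).

The compounds shown leave open how strongly any of the four inhibits, and whether sulfanyl in place of hydrogen changes that on either core.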